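The source may report more compounds than this note shows. Statements on the series, on what has been measured and on what is new or still open speak of the compounds shown alone.

Measured compounds in an ADME assay on MDBK cells (Bos taurus) for cytotoxicity; on this read-out lower numbers stand for higher toxicity in this test and higher numbers for lower toxicity in this test:
- compound 1, `Cc1ccccc1Cn1ccc2nc(-c3ccccc3)nc-2c1`, gives > 100000 nM, which is a limit of this assay rather than a number.
- compound 2, `Clc1cccc(Cn2ccc3nc(-c4ccccc4)nc-3c2)c1`, gives > 100000 nM, likewise a limit of this assay.

Among the measured compounds shown here, compound 1 therefore stands at the upper limit of this assay, with no measured number of its own; the one further value in the set, that of compound 2, is also a limit. For the measured compounds named here, the only measured step between these two, a step that the two limits leave unreadable from compound 1 to compound 2, cannot be read as a size, since (the limit of > 100000 nM in this assay, at which 2 of the 2 values shown sit).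

Compound 3, `FC(F)(F)c1ccccc1Cn1ccc2nc(-c3ccccc3)nc-2c1`, is not yet measured. It differs from compound 1 by trifluoromethyl in place of methyl on an aromatic carbon.

Going by the values given here, no measured step bears directly on a trifluoromethyl in place of methyl at this position. What the two measured compounds do show is that a change of the substituted phenyl on the saturated chain carbon left both values at the limit of this assay. On that basis no step beyond the scatter is expected from compound 1 to compound 3, and compound 3 is expected to sit at the same limit, a step that the limit leaves unreadable from compound 1 to compound 3.

For compound 3 the expected value in this assay is 150000 nM, with a range of 50000 nM to 400000 nM, most likely reported again only as a limit.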

Compound 3, half-maximal cytotoxic concentration: > 100000 nM
Compound 3: only a limit was reported; the forecaster's own chance of this, stated with the estimate: 80%; the middle value is on the limit's open side.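

Among the compounds shown here, compound 3 against compound 1, trifluoromethyl in place of methyl, gives no step that can be read in this assay: (the limit of > 100000 nM in this assay, at which 3 of the 3 values shown sit).

Still open, from the compounds shown here alone, are the size of any difference between compound 1 and compound 3, and whether any change on the substituted phenyl brings a value in this assay off this limit.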